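A ring swap on the sulfonamide of compound 2

The source may report more compounds than this note shows. Statements on the series, on what has been measured and on what is new or still open speak of the compounds shown alone.

Compound 1 `S=C(NNc1nncc2ccccc12)Nc1ccccc1` gives 39 nM
Compound 2 `O=S(=O)(Nc1ncccn1)c1ccc(Nc2nncc3ccccc23)cc1` gives 14 nM
Compound 3 `Clc1ccc(C(/C=C/c2ccccc2)=N\Nc2nncc3ccccc23)cc1` gives 3.3 nM

Compound 2 with 14 nM stands in the middle of the three in a functional assay on HeLa cells (Homo sapiens) for antiproliferative activity, read by sulforhodamine B assay, with a stated time of 72 h (a higher number here means a weaker inhibitor, a lower number a stronger inhibitor), as a stronger inhibitor than compound 1 and a weaker one than compound 3, and both gaps lie beyond the scatter.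

Compound 4 `Cc1cc(NS(=O)(=O)c2ccc(Nc3nncc4ccccc34)cc2)no1` has not yet been measured. It differs from compound 2 in one place: 5-methyl-1,2-oxazol-3-yl in place of pyrimidin-2-yl on a sulfonamide nitrogen with 5-methyl-1,2-oxazol-3-yl in place of pyrimidin-2-yl on a sulfonamide nitrogen.

Going by the values given here, no pair of measured compounds shows what a change at this place does, so the expectation rests on little evidence. The three measured compounds carry very different groups on their shared core, yet their numbers span only a modest range, from compound 3 at 3.3 nM to compound 1 at 39 nM in this assay as measured so far. A swap between two small rings should therefore move the number less than that. No shift beyond the scatter is expected in either direction, and the estimated step is a 1.1-fold higher number from compound 2 to compound 4 (0.06 log units; within the scatter) in this assay as a result. For compound 4 the expected value is 16 nM and the range from 6 nM to 45 nM is estimated to hold it.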

Compound 4, half-maximal inhibitory concentration: 13 nM
Compound 4: the middle estimate sits 1.2-fold (0.09 log units) above what was measured, within the range that was stated.
By their numbers in this assay, from the lowest: compound 3; then compounds 4 and 2 (each within the scatter of the next); then compound 1.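

This pair is the first among the compounds shown to isolate a single change, here on a sulfonamide nitrogen whose other neighbour is the sulfonyl sulfur. In this assay, putting 5-methyl-1,2-oxazol-3-yl in place of pyrimidin-2-yl gives a 1.1-fold lower number from compound 2 to compound 4 (0.03 log units; within the scatter), so the two compounds cannot be told apart, even though a five-membered aromatic ring stands in place of a six-membered one and one ring nitrogen gives way to an oxygen, while the counts of heavy atoms and hydrogen-bond acceptors stay the same. Nothing shown here explains why these two rings give such similar numbers.

Going by these compounds, what remains open is how far this tolerance extends, as both groups are small aromatic rings with two hetero atoms and this single pair cannot show whether other kinds of group would behave the same way. A plain hydrogen on the sulfonamide nitrogen, a longer chain such as butyl, or a ring carrying a carboxylic acid would test this position much more widely than the swap seen here.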